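The source may hold more compounds than are shown below. What is called first, only, known or untested is meant among the compounds shown, and "the series" means these compounds.

Measured so far:
Compound 1 `O=C(/C(=C\c1ccc(Br)cc1)Sc1ccc(Br)cc1)c1ccc(Br)cc1`: 1000 nM
Compound 2 `O=C(/C(=C\c1ccc(F)cc1Cl)Sc1ccc(Br)cc1)c1ccc(Br)cc1`: 1000 nM

In a functional assay on DU-145 cells (Homo sapiens) for inhibition, read by trypan blue exclusion, with a stated time of 96 h (on this read-out lower numbers stand for stronger inhibition of growth and higher numbers for weaker inhibition of growth), compound 2 gives 1000 nM, level with compound 1 at the digits shown. Compound 3 `O=C(/C(=C\c1ccc(Cl)cc1Cl)Sc1ccc(Br)cc1)c1ccc(Br)cc1` is the next analogue: chloro in place of fluoro on an aromatic carbon. This puts chloro in place of fluoro on an aromatic carbon, meta to a chloro group and para to a large group, turning 2-chloro-4-fluorophenyl into 2,4-dichlorophenyl. Within the data shown here, the only measured step that bears on it is no change at the digits printed from compound 1 to compound 2 (within the scatter), made at the same aryl group. Among the measured compounds shown here, no measured step isolates the exchange of fluoro for chloro, so the evidence is thin. Even so, a step beyond the scatter in this assay is not expected, and no direction is favoured. The expected move is no change at the digits printed from compound 2 to compound 3 (within the scatter). The estimate for compound 3 is 1000 nM, with an expected range of 450 nM to 2200 nM.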

Compound 3, concentration for 50% growth inhibition: 1000 nM
Compound 3: the middle estimate sits on the measured number at the digits printed, within the range that was stated.
By their numbers in this assay, from the lowest: compounds 1, 2 and 3 (each within the scatter of the next).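

In this assay, the exchange of fluoro for chloro on an aromatic carbon, meta to a chloro group and para to a large group, gives no change at the digits printed from compound 2 to compound 3 (within the scatter); unlike the earlier step, which replaced the whole aryl group, this one isolates a single halogen at this position. Replacing 4-bromophenyl with 2,4-dichlorophenyl gives no change at the digits printed from compound 1 to compound 3 (within the scatter), so a third halogen pattern on this aryl group joins the other two at the same printed value. Nothing in the available evidence accounts for this result.

Every group at this position so far is a halogen-bearing phenyl, so the compounds shown leave open how an amine, a methoxy group or a carboxylic acid there would read in this assay. On these data alone, the two 4-bromophenyl groups on the rest of the core also stay the same throughout, so their contribution remains open.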